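This account rests on a few compounds, and the source may have more. Where it says the series, first, only, none or still open, it means among the compounds named here.

Three members of one series have been measured in a functional assay on BGC-823 cells (Homo sapiens) for inhibition, read by MTT assay, with a stated time of 72 h; on this read-out higher numbers stand for weaker inhibition and lower numbers for stronger inhibition. Compound 1 `Cc1ccc(C(=O)Nc2ccc(CNC(=O)OCc3cccnc3)cc2)c(N2CCCC2)c1` gives > 100000 nM in this assay, which is a limit of the assay rather than a number. Compound 2 `O=C(NCc1ccc(NC(=O)c2cc(Cl)ccc2N2CCCC2)cc1)OCc1cccnc1` gives > 100000 nM in this assay, again a limit. Compound 3 `O=C(NCc1ccc(NC(=O)c2cc(Br)ccc2N2CCCC2)cc1)OCc1cccnc1` gives > 100000 nM in this assay, also a limit, so compound 3 stands where every measured member of the series stands. Within the data shown here, the only one-place step among the measured compounds, a step that the two limits leave unreadable from compound 2 to compound 3, cannot be sized, because of the limit of > 100000 nM in this assay, at which 3 of the 3 values shown sit. Compound 4 `O=C(NCc1ccc(NC(=O)c2cc(C(F)(F)F)ccc2N2CCCC2)cc1)OCc1cccnc1` differs from compound 3 in one place: trifluoromethyl in place of bromo on an aromatic carbon. Among the measured compounds shown here, no measured step with a readable size bears on this change, so the expectation rests only on the three limits already seen. Compound 4 is therefore expected to sit at the limit of the assay as well, with an expected step that the limit leaves unreadable from compound 3 to compound 4 that carries no real size. The estimate for compound 4 is 150000 nM in this assay, with a range from 60000 nM to 500000 nM.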

Compound 4, half-maximal inhibitory concentration: > 100000 nM
Compound 4: no number, only a limit (the forecaster's own chance of this, stated with the estimate: 85%); the middle value lies beyond the limit too.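

Among these compounds, no step can be sized from compound 3 to compound 4 or from compound 2 to compound 4, because these comparisons join limits rather than numbers: the limit of > 100000 nM in this assay, at which 4 of the 4 values shown sit. The compounds shown leave open how chloro, bromo and trifluoromethyl rank against one another in this assay, and whether any change to the shared core gives a readable value there.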